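The compounds below may be only part of what the source reports. "The series", "measured", "known", "first", "only" and "open" are said of these compounds alone.

Among the three compounds measured in an ADME assay on the whole organism for inhibition, with Echinochloa crus-galli var. formosensis as the target, with a stated time of 4 days (a lower number here means a stronger inhibitor, a higher number a weaker inhibitor), compound 2 `CC(C)N(c1nc(Cl)nc(N[C@@H](C)c2ccccc2)n1)C(C)C` gives the lowest number, 110 nM. Compound 1 `CC(C)N(c1nc(Cl)nc(N[C@H](C)c2ccccc2)n1)C(C)C` gives 6610 nM, and compound 3 `CCN(CC)c1nc(Cl)nc(N[C@H](C)c2ccccc2)n1` gives 24000 nM. The step of a 60-fold lower number from compound 1 to compound 2 (1.78 log units; beyond the scatter) is large, and because the fact that compounds 1 and 2 differ only in the configuration as drawn it shows how strongly the drawn configuration alone sets the result. The step of a 3.6-fold higher number from compound 1 to compound 3 (0.56 log units; beyond the scatter) is modest. Compound 4 `CCCN(C)c1nc(Cl)nc(N[C@@H](C)c2ccccc2)n1` carries methyl(propyl)amino in place of diisopropylamino on an aromatic carbon. The step from compound 1 to compound 3 bears on this change: there too another amino group replaced diisopropylamino on that aromatic carbon, and the number rose modestly. A modest rise in this assay is therefore expected here as well. Compound 4 is estimated at 330 nM, within a range of 100 nM to 1500 nM. The expected step is a 3.0-fold higher number from compound 2 to compound 4 (0.48 log units; beyond the scatter).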

Compound 4, half-maximal inhibitory concentration: 380 nM
Compound 4: middle estimate off by 1.2-fold (0.06 log units), on the low side; the measured number falls inside the stated range.
By their numbers in this assay, from the lowest: compound 2; then compound 4; then compound 1; then compound 3.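

The result in this assay is a 3.5-fold higher number from compound 2 to compound 4 (0.54 log units; beyond the scatter) and it shows that replacing diisopropylamino raises the number in the configuration drawn in compound 2 as well, not only in that of compound 1. Here the replacement is methyl(propyl)amino, a second amino group that differs from the diethylamino of compound 3. Nothing shown here explains this rise.

Still open, from the compounds shown here alone, is how a cyclic amine such as morpholine, or a longer chain such as dibutylamino, would behave at this position. Going by these compounds, the configuration drawn in compound 1 also remains untested with methyl(propyl)amino.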